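The compounds below may be only part of what the source reports. "The series", "measured", "known", "first", "only" and "open" are said of these compounds alone.

Compound 2 `CC1=CC[C@H](C(C)(C)NC(=S)N/N=C/c2cccc(Cl)c2)CC1` gives 6600 nM in a functional assay on PC-3 cells (Homo sapiens) for inhibition, read by sulforhodamine B assay, with a stated time of 48 h (a higher number here means a weaker inhibitor of growth, a lower number a stronger inhibitor of growth), the highest of the two numbers shown, while compound 1 `CC1=CC[C@H](C(C)(C)NC(=S)N/N=C/c2ccccc2Cl)CC1` gives 700 nM. Among the compounds with values here, the only measured step, a 9.4-fold higher number from compound 1 to compound 2 (0.97 log units; beyond the scatter), concerns 3-chlorophenyl in place of 2-chlorophenyl and does not replace the ring itself. Compound 3 `CC1=CC[C@H](C(C)(C)NC(=S)N/N=C/c2ccc[nH]2)CC1` differs from compound 2 by 1H-pyrrol-2-yl in place of 3-chlorophenyl on a carbon with a double bond to nitrogen. Within the data shown here, no measured step swaps one ring for another, so the step expected here, a 1.9-fold lower number from compound 2 to compound 3 (0.28 log units; within the scatter), is a modest one whose direction is uncertain. Compound 3 is therefore estimated at 3500 nM in this assay, with a range from 700 nM to 18000 nM.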

Compound 3, concentration for total growth inhibition: > 100000 nM
Compound 3 was reported as a limit; the forecaster's own chance of this, stated with the estimate: 10%; middle value at least 28-fold (1.45 log units) from the limit.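

In this assay, replacing the ring itself, rather than changing where its chlorine sits, gives an at least 15-fold higher number from compound 2 to compound 3 (1.18 log units; beyond the scatter) and an at least 140-fold higher number from compound 1 to compound 3 (2.15 log units; beyond the scatter). Compound 3 gives a limit, not a number: the limit of > 100000 nM in this assay, at which 1 of the 3 values shown sits. Among these three compounds, values below that limit appear only with the two chlorophenyl rings. This swap changes the ring size, the ring nitrogen and the chlorine together, and the three cannot be told apart here. A plain phenyl or a pyridyl ring at this place would help separate them.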